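Compound 3 to compound 4: a step at the limit

This account rests on a few compounds, and the source may have more. Where it says the series, first, only, none or still open, it means among the compounds named here.

Measured in an ADME assay on MT4 cells (Homo sapiens) for cytotoxicity, read by XTT assay, with a stated time of 5 days (a higher number here means that more compound is tolerated, a lower number that less compound is tolerated), each value is a limit and not a number:
- compound 1 `CNC(=O)[C@@H](NC(=O)[C@@](O)(CCCN(Cc1ccc(Br)cc1)NC(=O)[C@@H](NC(=O)OC)C(C)(C)C)Cc1ccccc1)C(C)(C)C` reads > 10000 nM
- compound 2 `CNC(=O)[C@H](CC(C)C)NC(=O)[C@@](O)(CCCN(Cc1ccc(Br)cc1)NC(=O)[C@@H](NC(=O)OC)C(C)(C)C)Cc1ccccc1` reads > 10000 nM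
- compound 3 `CNC(=O)[C@H](C)NC(=O)[C@@](O)(CCCN(Cc1ccc(Br)cc1)NC(=O)[C@@H](NC(=O)OC)C(C)(C)C)Cc1ccccc1` reads > 10000 nM

Compound 3 gives no number in this assay, only its limit of > 10000 nM here. All three compounds share (the limit of > 10000 nM in this assay, at which 3 of the 3 values shown sit).

Compound 4 `COC(=O)N[C@H](C(=O)NN(CCC[C@@](O)(Cc1ccccc1)C(=O)N[C@H](CO)C(C)(C)C)Cc1ccc(Br)cc1)C(C)(C)C` follows by 1-(hydroxymethyl)-2,2-dimethylpropyl in place of 1-(methylcarbamoyl)ethyl on an amide-type nitrogen.

Within the data shown here, three measured steps bear on this: a step that the two limits leave unreadable from compound 1 to compound 2, a step that the two limits leave unreadable from compound 1 to compound 3 and a step that the two limits leave unreadable from compound 2 to compound 3. None has a readable size.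

The expected step that the limit leaves unreadable from compound 3 to compound 4 stays within the scatter, with no direction expected. Compound 4 is estimated at 15000 nM, with an expected range of 8000 nM to 40000 nM, most likely reported again as a limit.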

Compound 4, half-maximal cytotoxic concentration: > 10000 nM
Compound 4: no number, only a limit (the forecaster's own chance of this, stated with the estimate: 85%); the middle value is on the limit's open side.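

In this assay compound 4 reads > 10000 nM, a limit and not a number. No step among compound 1, compound 2, compound 3 and compound 4 can be read: the limit of > 10000 nM in this assay, at which 4 of the 4 values shown sit.

Where the actual value of any of these compounds lies, and whether any of these changes shifts it, stays open.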